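A few compounds are considered here, and "the series" means these few. Any claim that something is new, unique, unknown or untested is made for them only; others in the source may bear on it.

Compound 1 `CCCC1=C(C(=O)OCC)C(c2cccc([N+](=O)[O-])c2)C(C(=O)OCC)=C(C)N1`: 105 nM
Compound 2 `CCCCC1=C(C(=O)OCC)C(c2cccc([N+](=O)[O-])c2)C(C(=O)OCC)=C(C)N1`: 20 nM
Compound 3 `C#CCCOC(=O)C1=C(C)NC(C)=C(C(=O)OC)C1c1cccc([N+](=O)[O-])c1`: 35 nM

All three were tested in a functional assay on HEK293 cells for antagonist activity at Voltage-dependent L-type calcium channel subunit alpha-1D (Rattus norvegicus), read by FLIPR; on this read-out lower numbers stand for stronger inhibition and higher numbers for weaker inhibition. Compound 3 has the second highest of the three numbers; compound 2 sits within the scatter of it, while compound 1 lies beyond the scatter above it. Compound 4 `COC(=O)C1=C(C)NC(C)=C(C(=O)OCCc2ccc(Cl)cc2)C1c1cccc([N+](=O)[O-])c1` differs from compound 3 by 4-chlorophenyl in place of ethynyl on a saturated chain carbon, two bonds along the chain from an oxygen next to a carbonyl group. Among the measured compounds shown here, the only measured step, a 5.3-fold lower number from compound 1 to compound 2 (0.72 log units; beyond the scatter), concerns the chain on a double-bonded ring carbon and not the ester chain, so no measured step bears directly on this change. Compound 4 is therefore expected to show at most a small step, a 1.2-fold lower number from compound 3 to compound 4 (0.07 log units; within the scatter), with a wide margin either way. Compound 4 is estimated to give 30 nM, between 8 nM and 120 nM.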

Compound 4, half-maximal inhibitory concentration: 39 nM
Estimate against measurement, compound 4: 1.3-fold (0.11 log units) below; the range from low to high includes it.
By their numbers in this assay, from the lowest: compounds 2, 3 and 4 (each within the scatter of the next); then compound 1.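

In this assay the change gives a 1.1-fold higher number from compound 3 to compound 4 (0.05 log units; within the scatter) and stays within the scatter. On a saturated chain carbon, two bonds along the chain from an oxygen next to a carbonyl group, 4-chlorophenyl with 7 heavy atoms and an aromatic ring thus takes the place of ethynyl with 2 heavy atoms, with no measurable effect on the number. No available evidence accounts for this result. From the compounds shown here alone, whether an amine or a carboxylic acid at this place would leave the number unchanged stays open. So does whether a longer chain ending in 4-chlorophenyl would do the same.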